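Trimming a bromofluorobenzyl arm down to ethyl

This account rests on a few compounds, and the source may have more. Where it says the series, first, only, none or still open, it means among the compounds named here.

Compound 2, `O=C(O)CN1C(=O)/C(=C/c2nc3ccccc3n2Cc2ccc(Br)cc2F)SC1=S`, stands at the edge of what a functional assay on HeLa cells (Homo sapiens) for cytotoxicity, read by MTT assay, with a stated time of 48 h (a lower number here means a stronger inhibitor, a higher number a weaker inhibitor), can report: in this assay compound 2 gives only a limit, > 50000 nM, and no number. That is the limit of > 50000 nM in this assay, at which 1 of the 3 values shown sits. Its two measured relatives sit inside the range: compound 1, `O=C(O)CN1C(=O)/C(=C/c2nc3ccccc3n2Cc2ccc(Br)cc2)SC1=S`, gives 12900 nM in this assay, and compound 3, `COc1cc(Cn2c(/C=C3\SC(=S)N(CC(=O)O)C3=O)nc3ccccc32)cc(OC)c1`, gives 17700 nM. Adding fluoro in place of hydrogen on an aromatic carbon gave an at least 3.8-fold higher number from compound 1 to compound 2 (0.58 log units; beyond the scatter), while swapping the ring gave a 1.4-fold higher number from compound 1 to compound 3 (0.14 log units; within the scatter) and, starting from the limit, an at least 2.8-fold lower number from compound 2 to compound 3 (0.45 log units; beyond the scatter).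

Compound 4, `CCn1c(/C=C2\SC(=S)N(CC(=O)O)C2=O)nc2ccccc21`, differs from compound 2 by methyl in place of 4-bromo-2-fluorophenyl on a saturated chain carbon bound to an aromatic nitrogen. Among the compounds with values here, no measured step removes the ring altogether, so only the ring-swap steps bear on this one, and they show that leaving compound 2 can bring the number back into range, as an at least 2.8-fold lower number from compound 2 to compound 3 (0.45 log units; beyond the scatter) did. Compound 4 is therefore expected to land near 30000 nM, between 10000 nM and 90000 nM, which would mean a step of an at least 1.6-fold lower number from compound 2 to compound 4 (0.22 log units; that floor lies within the scatter) in this assay.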

Compound 4, half-maximal inhibitory concentration: 3520 nM
Beside the measured number, compound 4's estimate is 8.5-fold (0.93 log units) above it; measured number outside the range, below it.
By their numbers in this assay, from the lowest: compound 4; then compounds 1 and 3 (each within the scatter of the next). At a limit, above all of these: compound 2.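

Within the data shown here, at this position, the earlier compounds only exchanged one aromatic ring for another, whereas 4-bromo-2-fluorobenzyl to ethyl removes the ring altogether, and in this assay the change gives an at least 14-fold lower number from compound 2 to compound 4 (1.15 log units; beyond the scatter) once the ring is gone. The result does not depend on which ring is replaced: the same change also gives a 5.0-fold lower number from compound 3 to compound 4 (0.70 log units; beyond the scatter) and a 3.7-fold lower number from compound 1 to compound 4 (0.56 log units; beyond the scatter), so compound 4 is the strongest of the four and no ring is needed here for activity in this test. The first of these steps is only a floor, as compound 2 gives a limit and no number: the limit of > 50000 nM in this assay, at which 1 of the 4 values shown sits.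

Still open, as far as these compounds go, is whether a propyl chain would keep this activity, or whether a chain ending in an amine would match ethyl. A single small group also cannot separate the loss of the ring from the shortening of the arm.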